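The source may hold more compounds than are shown below. What is called first, only, known or untested is meant among the compounds shown, and "the series" means these compounds.

Measured in a physicochemical assay for acid dissociation:
Compound 1 `CCN(C1=NCCN1)c1c(Br)cccc1Br`: 11.1
Compound 2 `CCCCN(C1=NCCN1)c1c(Br)cccc1Br`: 11
Compound 3 `CC(C)N(C1=NCCN1)c1c(Br)cccc1Br`: 11.2

Compound 3, at 11.2, stands within the scatter of both other compounds. The measured steps to it are a number 0.10 log units higher from compound 1 to compound 3 (within the scatter) and a number 0.20 log units higher from compound 2 to compound 3 (within the scatter).

The next structure is compound 4 `C=CCN(C1=NCCN1)c1c(Br)cccc1Br`, with allyl in place of isopropyl on a nitrogen on an aromatic ring. Going by the values given here, no measured compound carries allyl, so no step measures this group directly. The nearest evidence is the set of changes already made to the chain on that nitrogen. Besides the two steps above, there is a number 0.10 log units lower from compound 1 to compound 2 (within the scatter). Isopropyl in place of butyl is the closest of these in kind, and it gave a number 0.20 log units higher from compound 2 to compound 3 (within the scatter). As all three steps stay within the scatter, no step beyond the scatter is expected in this assay. The estimated step is a number 0.20 log units lower from compound 3 to compound 4 (within the scatter). For compound 4 the expected value is 11, with an estimated range from 10.7 to 11.3.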

Compound 4, acid dissociation constant: 10.7
For compound 4 the middle estimate is 0.30 log units above the measured one, and the stated range covers the measured number.
By their numbers in this assay, from the lowest: compounds 4, 2, 1 and 3 (each within the scatter of the next, the first and the last beyond it).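

In this assay, going by these compounds alone, allyl is the first change to the chain on the nitrogen on an aromatic ring that gives a step beyond the scatter: a number 0.50 log units lower from compound 3 to compound 4 (beyond the scatter) and a number 0.40 log units lower from compound 1 to compound 4 (beyond the scatter). The separation is only partial, as a number 0.30 log units lower from compound 2 to compound 4 (within the scatter), so compound 4 stands clear of compound 1 and compound 3 but not of compound 2. Nothing at hand accounts for this shift, which remains an observation about this single chain with a double bond outside aromatic rings.

The compounds shown leave open whether a propargyl or a benzyl group on this nitrogen would fall with allyl or with the saturated chains. They also leave open whether allyl in place of isopropyl would give a similar step on a core with chlorine in place of bromine.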